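The source may hold more compounds than are shown below. What is called first, only, known or untested is meant among the compounds shown, and "the series" means these compounds.

In a functional assay on VCaP cells (Homo sapiens) for antiproliferative activity, read by propidium iodide staining, with a stated time of 96 h (a higher number here means a weaker inhibitor, a lower number a stronger inhibitor), compound 1 `CC(O)(CS(=O)(=O)c1ccc(S(F)(F)(F)(F)F)cc1)C(=O)Nc1cccc(S(F)(F)(F)(F)F)c1` gives 17200 nM while compound 2 `CC(O)(CS(=O)(=O)c1cccc(S(F)(F)(F)(F)F)c1)C(=O)Nc1cccc(S(F)(F)(F)(F)F)c1` gives 19000 nM and compound 3 `CC(O)(CS(=O)(=O)c1ccc(F)cc1)C(=O)Nc1cccc(S(F)(F)(F)(F)F)c1` gives 37900 nM on the same read-out. Compound 3 thus sits within the scatter of compound 2 and just beyond it from compound 1. Compound 4 `CC(O)(CS(=O)(=O)c1cccc(C(F)(F)F)c1)C(=O)Nc1cccc(S(F)(F)(F)(F)F)c1` carries 3-(trifluoromethyl)phenyl in place of 4-fluorophenyl on a sulfonyl sulfur. For the measured compounds named here, the one measured step bearing on this is a 2.2-fold higher number from compound 1 to compound 3 (0.34 log units; beyond the scatter) and it is modest, with the single fluorine giving the higher number. A small move to a lower number is therefore expected, and the estimated step is a 1.6-fold lower number from compound 3 to compound 4 (0.20 log units; within the scatter) in this assay with nothing clearly beyond the scatter. Compound 4 is estimated at 24000 nM with 11000 nM to 50000 nM as the expected range.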

Compound 4, half-maximal inhibitory concentration: 35500 nM
For compound 4 the middle estimate is 1.5-fold (0.17 log units) below the measured one; low and high end bracket the measured number.
By their numbers in this assay, from the lowest: compounds 1, 2, 4 and 3 (each within the scatter of the next, the first and the last beyond it).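

In this assay, 3-(trifluoromethyl)phenyl in place of 4-fluorophenyl on the sulfonyl sulfur gives a 1.1-fold lower number from compound 3 to compound 4 (0.03 log units; within the scatter), so the larger aryl group leaves the read-out unchanged within the scatter. Trifluoromethyl in place of pentafluorosulfanyl on this ring gives a 1.9-fold higher number from compound 2 to compound 4 (0.27 log units; within the scatter), which also stays within the scatter, so these two aryl groups cannot be told apart here. No available evidence accounts for these results. The compounds shown leave open how an amine or a carboxylic acid on this ring would read out, and whether any group on the sulfonyl sulfur could give a much lower number.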